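Adding a Trifluoromethyl Group to Compound 1

The compounds below may be only part of what the source reports. "The series", "measured", "known", "first", "only" and "open" are said of these compounds alone.

Compound 1 `C[C@@H](NC(=O)Nc1ccccc1F)c1ccccc1`: 95%
Compound 2 `C[C@@H](NC(=O)Nc1ccccc1Cl)c1ccccc1`: 103%
Compound 3 `C[C@@H](NC(=O)Nc1c(F)cccc1F)c1ccccc1`: 100%

In an ADME assay on the whole organism with Oryza sativa as the target, tested at 1 uM (on this read-out higher numbers stand for a weaker effect at the one concentration tested and lower numbers for a stronger effect), compound 1 gives 95%, the lowest of the three numbers, yet compound 3 with 100% and compound 2 with 103% both sit within the scatter of it. Compound 4 `C[C@@H](NC(=O)Nc1cccc(C(F)(F)F)c1F)c1ccccc1` differs from compound 1 in one place: trifluoromethyl in place of hydrogen on an aromatic carbon. Going by the values given here, two measured steps bear on this change, since both also alter the same ring: a number 8 percentage points higher from compound 1 to compound 2 (within the scatter) and a number 5 percentage points higher from compound 1 to compound 3 (within the scatter). Neither moved the number beyond the scatter, and nothing measured points elsewhere for a trifluoromethyl group. The step is therefore expected to be small, a number 2 percentage points higher from compound 1 to compound 4 (within the scatter), with no change beyond the scatter. Compound 4 is estimated at 97%, between 85% and 110%.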

Compound 4, a percentage reported as activity, at one concentration (the size of the read-out at that concentration, not a potency): 99%
Compound 4: middle estimate off by 2 percentage points, on the low side; the range from low to high includes it.
By their numbers in this assay, from the lowest: compounds 1, 4, 3 and 2 (each within the scatter of the next).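

In this assay, trifluoromethyl in place of hydrogen on this aromatic carbon, ortho to a fluoro group, gives a number 4 percentage points higher from compound 1 to compound 4 (within the scatter). The earlier steps shown here changed only single halogen atoms on the ring, whereas this one shows that a group of several heavy atoms can sit at this place without moving the number beyond the scatter. No measurement shown here explains this result. The compounds shown leave open whether an amine, a carboxylic acid or a longer chain on this carbon would move the number beyond the scatter.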